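The source may hold more compounds than are shown below. What is called first, only, known or untested is meant among the compounds shown, and "the series" means these compounds.

Among the measured compounds shown here, in a functional assay on A549 cells (Homo sapiens) for inhibition, read by MTT assay, with a stated time of 48 h (on this read-out lower numbers stand for stronger inhibition and higher numbers for weaker inhibition), compound 2 `COc1cc(/C=N/Nc2nc(-c3cc(C(F)(F)F)cc(C(F)(F)F)c3)cs2)cc(Br)c1OC` gives 94200 nM, the highest of the three numbers measured so far. Compound 1 `Fc1ccc(/C=N/Nc2nc(-c3cc(C(F)(F)F)cc(C(F)(F)F)c3)cs2)cc1F` gives 6230 nM and compound 3 `COc1cc(/C=N/Nc2nc(-c3ccc(C(F)(F)F)cc3)cs2)cc(Br)c1OC` gives 18300 nM in this assay. Compound 4 `COc1cc(/C=N/Nc2nc(-c3cc(C(F)(F)F)cc(C(F)(F)F)c3)cs2)c(Br)c(Br)c1OC` differs from compound 2 by bromo in place of hydrogen on an aromatic carbon. For the measured compounds named here, the only step measured between neighbours, a 15-fold higher number from compound 1 to compound 2 (1.18 log units; beyond the scatter), swaps the whole aryl group on the carbon double-bonded to nitrogen, so no measured step bears directly on adding a second bromo group. With that gap in the data, the step of a 1.1-fold higher number from compound 2 to compound 4 (0.03 log units; within the scatter) is expected to stay close to no change beyond the scatter. Compound 4 is therefore estimated at 100000 nM, within a range from 30000 nM to 300000 nM.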

Compound 4, half-maximal inhibitory concentration: > 100000 nM
Compound 4 ended at the assay's limit; the forecaster's own chance of this, stated with the estimate: 20%; the middle value lies on the limit itself.
By their numbers in this assay, from the lowest: compound 1; then compound 3; then compound 2. At a limit, above all of these: compound 4.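

Putting bromo in place of hydrogen on this aromatic carbon, ortho to a bromo group, gives an at least 1.0-fold higher number from compound 2 to compound 4 (0.02 log units; that floor lies within the scatter). Compound 4 reaches a limit of this assay rather than a true number: the limit of > 100000 nM in this assay, at which 1 of the 4 values shown sits. Among the compounds shown here, this is the first view of a change at this position: the added bromo gives no sign of stronger inhibition, but how much weaker compound 4 may be, if at all, stays unknown.

Still open, going by these compounds, is how a different group on this same carbon, such as an amine or a carboxylic acid, would behave in this assay.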